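The source may hold more compounds than are shown below. What is called first, only, known or untested is meant among the compounds shown, and "the series" means these compounds.

In an ADME assay on SK-OV-3 cells (Homo sapiens) for cytotoxicity, read by sulforhodamine B assay, with a stated time of 48 h, tested at 10 uM (on this read-out higher numbers stand for more inhibition at the one concentration tested (going by the name of the read-out) and lower numbers for less inhibition), compound 1, with the structure `CCCCc1cn(C(c2ccccc2)c2cc3cc(Br)ccc3nc2OC)nn1`, gives 11.1%, and compound 2, with the structure `CCOC(=O)c1cn(C(c2ccccc2)c2cc3cc(Br)ccc3nc2OC)nn1`, gives 2.01%. Of the two numbers shown, that of compound 2 is the smaller, but the gap to compound 1 lies within the scatter: the step of a number 9.1 percentage points lower from compound 1 to compound 2 (within the scatter) is the only measured step and it is not a difference that repeated measurement would reliably reproduce.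

Compound 3, with the structure `CCCCCc1cn(C(c2ccccc2)c2cc3cc(Br)ccc3nc2OC)nn1`, has not yet been measured in this assay. It differs from compound 2 by pentyl in place of ethoxycarbonyl on an aromatic carbon. Going by the values given here, the one measured step bears on this change only loosely: it exchanged butyl for ethoxycarbonyl and moved the number within the scatter, and the new change reverses that exchange and adds one carbon to the chain. Because a number 9.1 percentage points lower from compound 1 to compound 2 (within the scatter) stayed within the scatter, compound 3 is expected to land near compound 1 rather than apart from it, and the step of a number 8 percentage points higher from compound 2 to compound 3 (within the scatter) is expected to stay within the scatter. Compound 3 is therefore estimated at 10%, within a range from 0% to 24%.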

Compound 3, a percentage reported as inhibition, at one concentration (the size of the read-out at that concentration, not a potency): 10.5%
For compound 3 the middle estimate is 0.5 percentage points below the measured one; measured number inside the range.
By their numbers in this assay, from the lowest: compounds 2, 3 and 1 (each within the scatter of the next).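

In this assay, putting pentyl in place of ethoxycarbonyl on this aromatic carbon of the five-membered ring gives a number 8.5 percentage points higher from compound 2 to compound 3 (within the scatter) and thus adds a second exchange at this position that the read-out does not separate from the scatter. The methyl added at the end of the butyl chain gives a number 0.6 percentage points lower from compound 1 to compound 3 (within the scatter) and shows that, across butyl and pentyl, this one-carbon extension is likewise not resolved, so the three compounds cannot be placed in any order here. No measurement is available that would account for these numbers.

What a longer chain such as octyl, a carboxylic acid or an amine would do at this position remains open, as only butyl, pentyl and ethoxycarbonyl are shown there and none of them stands beyond the scatter from another. Going by these compounds, it also remains open whether this position can move the read-out at all, or whether a change elsewhere on the shared core, such as an amine in place of the bromine, would be needed to do so.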